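Another Amine Ring at the End of the Chain

A few compounds are considered here, and "the series" means these few. Any claim that something is new, unique, unknown or untested is made for them only; others in the source may bear on it.

Measured compounds:
compound 1 `COc1cc2c(Oc3ccc(NC(=O)C4(c5nnc(-c6ccc(F)cc6)o5)CC4)cc3F)ccnc2cc1OCCCN1CCCC1` — 150 nM
compound 2 `COc1cc2c(Oc3ccc(NC(=O)C4(c5nnc(-c6ccc(F)cc6)o5)CC4)cc3F)ccnc2cc1OCCCN1CCN(C)CC1` — 143 nM

Both compounds were tested in a functional assay on A549 cells (Homo sapiens) for antiproliferative activity, read by MTT assay, with a stated time of 72 h; a lower number here means a stronger inhibitor, a higher number a weaker inhibitor. Compound 2 and compound 1 sit side by side on the numbers shown: the step of a 1.0-fold lower number from compound 1 to compound 2 (0.02 log units; within the scatter) lies within the scatter, so neither compound can be set above the other, and compound 2 is simply the one whose number is nearest the lower edge of this small pair.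

Compound 3 `COc1cc2c(Oc3ccc(NC(=O)C4(c5nnc(-c6ccc(F)cc6)o5)CC4)cc3F)ccnc2cc1OCCCN1CCC(C)CC1` has not yet been measured. It differs from compound 2 only at the terminus of the chain: 4-methylpiperidin-1-yl in place of 4-methylpiperazin-1-yl on a saturated chain carbon, three bonds along the chain from an oxygen on an aromatic ring. Among the measured compounds shown here, the one measured step that bears on this change, a 1.0-fold lower number from compound 1 to compound 2 (0.02 log units; within the scatter), also exchanged the amine ring on a saturated chain carbon, three bonds along the chain from an oxygen on an aromatic ring, and it produced no movement beyond the scatter. On that basis no step beyond the scatter is expected for compound 3 in this assay either, in neither direction.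

Compound 3 is therefore estimated at 150 nM, with a range from 70 nM to 320 nM. The expected step from compound 2 is a 1.0-fold higher number from compound 2 to compound 3 (0.02 log units; within the scatter).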

Compound 3, half-maximal inhibitory concentration: 120 nM
For compound 3 the middle estimate is 1.3-fold (0.10 log units) above the measured one, within the range that was stated.
By their numbers in this assay, from the lowest: compounds 3, 2 and 1 (each within the scatter of the next).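

In this assay, replacing 4-methylpiperazin-1-yl with 4-methylpiperidin-1-yl on a saturated chain carbon, three bonds along the chain from an oxygen on an aromatic ring, gives a 1.2-fold lower number from compound 2 to compound 3 (0.08 log units; within the scatter), and replacing pyrrolidin-1-yl with the same group gives a 1.3-fold lower number from compound 1 to compound 3 (0.10 log units; within the scatter). The earlier step exchanged one whole amine ring for another, whereas the step to compound 3 keeps 7 heavy atoms and a six-membered non-aromatic ring and goes from 2 hetero atoms to 1, so the second ring nitrogen of compound 2 is not required for a number within the scatter of compound 2. All three amine rings at this position now lie within the scatter of one another, and nothing measured here explains this lack of separation.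

From the compounds shown here alone, all three compounds carry a ring amine on the same propyl chain, so it remains open how this assay would read with morpholin-4-yl, an open-chain dimethylamino group or a carboxylic acid at the chain end. A shorter or longer chain also remains untested among the compounds shown, so the reach of this flat result along the chain is unknown.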